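Hydroxy in place of methoxy: a step from compound 2

A few compounds are considered here, and "the series" means these few. Any claim that something is new, unique, unknown or untested is made for them only; others in the source may bear on it.

Of the compounds shown here, two have been measured in a functional assay on HL-60 cells (Homo sapiens) for inhibition, read by MTT assay; a higher number here means a weaker inhibitor, a lower number a stronger inhibitor. Compound 1, `COC(=O)c1c(C)cc(Oc2cc(C)cc(O)c2)cc1O`, gives > 10000 nM there, which is a limit of the assay and not a number. Compound 2, `COc1cc(C)cc(Oc2cc(C)cc(O)c2)c1`, gives > 10000 nM in this assay, again a limit rather than a measured number. Compound 2 thus stands at the same limit as compound 1; both values sit at the limit of > 10000 nM in this assay, at which 2 of the 2 values shown sit. The two differ in more than one place. For the measured compounds named here, no step between measured compounds is available.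

Compound 3, `Cc1cc(O)cc(Oc2cc(C)cc(O)c2)c1`, is the compound still to be measured. It differs from compound 2 as follows: hydrogen in place of methyl on an oxygen on an aromatic ring. Cut one bond further out, the change reads methoxy to hydroxy, on an oxygen on an aromatic ring whose other neighbour is an aromatic carbon.

Going by the values given here, with both known values at the limit, there is no measured step to lean on. For this change, no step beyond the usual scatter is expected from compound 2 to compound 3 in this assay; the expected step is a step that the limit leaves unreadable from compound 2 to compound 3. Compound 3 is expected to give about 15000 nM in this assay, within a range from 3000 nM to 60000 nM, most likely once more reported only as a limit.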

Compound 3, half-maximal inhibitory concentration: > 10000 nM
Compound 3: only a limit was reported (the forecaster's own chance of this, stated with the estimate: 75%); the middle value does not contradict the limit.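

In this assay compound 3 gives > 10000 nM, a limit and not a number. No step from compound 2 or from compound 1 to compound 3 can be read: the limit of > 10000 nM in this assay, at which 3 of the 3 values shown sit.

The compounds shown leave open whether methoxy to hydroxy changes inhibition at all, and how far past the limit any of the three compounds lies.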